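Phenyl in Place of Methyl: Expected Paw Edema Inhibition

The source may hold more compounds than are shown below. What is called first, only, known or untested is meant among the compounds shown, and "the series" means these compounds.

Measured compounds:
compound 1 `CCOC(=O)c1nn(-c2ccc(Cl)cc2)c(-c2ccc(OC)cc2OC)c1-c1ccccc1`: 15%
compound 2 `COc1ccc(-c2c(C)c(C(=O)O)nn2-c2ccc(Cl)cc2)c(OC)c1`: 22.8%

In a functional assay on the whole organism (strain albino) for inhibition, with Rattus norvegicus as the target, read by paw edema, with stated times of 30 min and 3 h, at a dose of 25 mg/kg by the intraperitoneal route (a higher number here means more inhibition at the dose given (going by the name of the read-out), a lower number less inhibition), compound 1 gives 15% and compound 2 gives 22.8%. Compound 2 stands at the head of these two numbers, but its difference from compound 1 is within the scatter, so the two cannot be told apart. Compound 3 `COc1ccc(-c2c(-c3ccccc3)c(C(=O)O)nn2-c2ccc(Cl)cc2)c(OC)c1` is not yet measured; it differs from compound 2 by phenyl in place of methyl on an aromatic carbon. Within the data shown here, no step between measured compounds is given, so the expected step in this assay is none beyond the scatter. Compound 3 is expected to give 19%, ranging from 8% to 30%. That means an expected step of a number 3.8 percentage points lower from compound 2 to compound 3 (within the scatter).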

Compound 3, a percentage reported as inhibition, in the whole organism at one dose (the size of the read-out at that dose, not a potency): 45.5%
Beside the measured number, compound 3's estimate is 26.5 percentage points below it, outside the stated range (above it).
By their numbers in this assay, from the lowest: compounds 1 and 2 (each within the scatter of the next); then compound 3.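

Phenyl in place of methyl on this aromatic carbon gives a number 22.7 percentage points higher from compound 2 to compound 3 (beyond the scatter) in this assay, so this position of the shared core does respond to the group placed on it. With the phenyl kept, hydrogen in place of ethyl on the oxygen next to the carbonyl group gives a number 30.5 percentage points higher from compound 1 to compound 3 (beyond the scatter), which shows that the free carboxy group goes with a clearly higher number than the ethyl ester. Nothing at hand explains either step.

On these data alone, it remains open whether a propyl chain or a pyridine ring on this carbon would match the phenyl. Also open, as far as these compounds go, is how an amide in place of the carboxy group would read.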